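Butyl Gives Way to 1-Methoxy-1-methylethyl in Compound 4

A few compounds are considered here, and "the series" means these few. Any claim that something is new, unique, unknown or untested is made for them only; others in the source may bear on it.

Compound 3 `CCCC[C@@H](O)C(=O)N1N=CC[C@H]1C(=O)NCc1cc(Cl)ccc1-n1cnnn1` was measured in an ADME assay on liver for metabolic stability, with Liver microsome (Homo sapiens) as the target, read by LC-MS, using microsomes; a lower number here means slower removal, a higher number faster removal of the compound. Compound 3 gives < 12 mL.min-1.g-1, which is a limit of the assay and not a number. Compound 1 `Cc1cccc([C@@H](O)C(=O)N2N=CC[C@H]2C(=O)NCc2cc(Cl)ccc2-n2cnnn2)c1` gives < 12 mL.min-1.g-1, also a limit. Compound 2 `CC(C)CC[C@@H](O)C(=O)N1N=CC[C@H]1C(=O)NCc1cc(Cl)ccc1-n1cnnn1` gives a true number, 47 mL.min-1.g-1.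

Compound 4 `COC(C)(C)[C@@H](O)C(=O)N1N=CC[C@H]1C(=O)NCc1cc(Cl)ccc1-n1cnnn1` has 1-methoxy-1-methylethyl in place of butyl on a saturated chain carbon bound to a carbonyl carbon and an oxygen on a saturated carbon. Among the measured compounds shown here, two measured steps bear on this change at the same chain. One is an at least 3.9-fold higher number from compound 1 to compound 2 (0.59 log units; beyond the scatter), and the other is an at least 3.9-fold lower number from compound 2 to compound 3 (0.59 log units; beyond the scatter). Both lie beyond the scatter, so small edits to this chain can matter. For the measured compounds named here, no measured compound carries an oxygen in this group, so the direction stays uncertain.

Going by an at least 3.9-fold lower number from compound 2 to compound 3 (0.59 log units; beyond the scatter), a modest rise in this assay is the expected direction, though the limit of < 12 mL.min-1.g-1 in this assay, at which 2 of the 3 values shown sit, may still apply. The expected change is an at least 1.1-fold higher number from compound 3 to compound 4 (0.06 log units; that floor lies within the scatter). For compound 4 the estimated value is 14 mL.min-1.g-1, with an expected range of 6 mL.min-1.g-1 to 35 mL.min-1.g-1.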

Compound 4, intrinsic clearance in microsomes: < 12 mL.min-1.g-1
Compound 4 ended at the assay's limit; the forecaster's own chance of this, stated with the estimate: 50%; middle value at least 1.1-fold (0.06 log units) away from the limit.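

Compound 4 shows that a group carrying an oxygen can sit on this saturated chain carbon and still read at the limit in this assay, a limit of the assay and not a number. Set against the isopentyl group, the change gives an at least 3.9-fold lower number from compound 2 to compound 4 (0.59 log units; beyond the scatter), while the steps to compound 4 from compound 1 and compound 3 cannot be read, as each joins two limits. Isopentyl in compound 2 remains the only group shown here with a true number: the limit of < 12 mL.min-1.g-1 in this assay, at which 3 of the 4 values shown sit.

From the compounds shown here alone, how far under the limit compound 1, compound 3 and compound 4 really lie stays unknown, so their groups cannot be ranked against one another. Also open, going by these compounds, is whether an amine or a hexyl chain in this place would stay at the limit or give a true number, as isopentyl does.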